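A few compounds are considered here, and "the series" means these few. Any claim that something is new, unique, unknown or untested is made for them only; others in the source may bear on it.

Compound 1 `CCC/C=C\C(=O)Nc1cc(Nc2nccc(-c3cn(C)c4ccccc34)n2)c(OC)cc1N(C)CCN(C)C` gives 1220 nM in a functional assay on NCI-H1975 cells (Homo sapiens) for antiproliferative activity, read by MTT assay, with a stated time of 72 h; on this read-out lower numbers stand for stronger inhibition and higher numbers for weaker inhibition. Compound 2 `CCC/C=C\C(=O)Nc1cc(Nc2nc(C)cc(-c3cn(C)c4ccccc34)n2)c(OC)cc1N(C)CCN(C)C` carries methyl in place of hydrogen on an aromatic carbon and gives 254 nM, a step of a 4.8-fold lower number from compound 1 to compound 2 (0.68 log units; beyond the scatter). Compound 3 `C=CC(=O)Nc1cc(Nc2nccc(-c3cn(C)c4ccc(F)cc34)n2)c(OC)cc1N(C)CCN(C)C` gives 254 nM; its core differs from that of compound 1, but the difference between the two cores is not broken down here. Compound 4 `C=CC(=O)Nc1cc(Nc2nc(C)cc(-c3cn(C)c4ccc(F)cc34)n2)c(OC)cc1N(C)CCN(C)C` bears methyl in place of hydrogen on an aromatic carbon, the same kind of change as in compound 2, though here the place is meta to a 5-fluoro-1-methyl-1H-indol-3-yl group rather than meta to a 1-methyl-1H-indol-3-yl group. The step from compound 3 to compound 4 is expected to be a 2.5-fold lower number from compound 3 to compound 4 (0.40 log units; beyond the scatter), resting on the earlier step of a 4.8-fold lower number from compound 1 to compound 2 (0.68 log units; beyond the scatter), though compound 3 already sits level with compound 2. Compound 4 is therefore estimated at 100 nM, between 45 nM and 250 nM.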

Compound 4, half-maximal inhibitory concentration: 3830 nM
The estimate for compound 4 lay 38-fold (1.58 log units) below the measured number; measured number outside the range, above it.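

On the core of compound 3, methyl in place of hydrogen gives a 15-fold higher number from compound 3 to compound 4 (1.18 log units; beyond the scatter) in this assay, so the gain seen on the core of compound 1 does not carry over, and the direction of the step reverses: the same change on two cores in this assay, a 4.8-fold lower number (0.68 log units; beyond the scatter) from compound 1 to compound 2 and a 15-fold higher number (1.18 log units; beyond the scatter) from compound 3 to compound 4, 72-fold (1.86 log units) apart, beyond the scatter of two such steps.
In these two pairs, then, the outcome of this change depends on the core it is made on. For the compounds shown here, they do not show which difference between the two cores goes with the reversal, and each core supplies only a single pair, so no wider rule follows.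

On these data alone, whether an ethyl group or a chlorine atom at the same place would split in the same way remains open. So does the outcome on further cores.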